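The source may hold more compounds than are shown below. What is called first, only, known or untested is meant among the compounds shown, and "the series" means these compounds.

Measured compounds in this series:
compound 1 `O=S(=O)(Nc1ccc(-c2nc3ccccc3o2)cc1)c1cccc(Cl)c1`: > 63000 nM
compound 2 `Cc1cccc(S(=O)(=O)Nc2ccc3oc(-c4ccccc4)nc3c2)c1`: > 63000 nM
compound 3 `Cc1ccc(S(=O)(=O)Nc2ccc3oc(-c4ccccc4)nc3c2)cc1`: > 63000 nM

In an assay on isolated protein for inhibition of malate dehydrogenase, mitochondrial (Sus scrofa), with stated times of 45 min and 30 min (on this read-out lower numbers stand for stronger inhibition and higher numbers for weaker inhibition), compound 1 gives > 63000 nM, which is a limit of the assay and not a number. Compound 2 gives > 63000 nM in this assay, also a limit. Compound 3 gives > 63000 nM in this assay, again a limit. All three values sit at the limit of > 63000 nM in this assay, at which 3 of the 3 values shown sit, so compound 1 cannot be placed relative to compound 2 or compound 3 on the numbers shown. Among the measured compounds shown here, the only step between measured compounds that differ in one place, a step that the two limits leave unreadable from compound 2 to compound 3, is unreadable because both ends are limits, and it concerns a different exchange on the sulfonyl sulfur than the one followed here.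

Compound 4 `O=S(=O)(Nc1ccc(-c2nc3ccccc3o2)cc1)c1ccc(F)cc1` differs from compound 1 by 4-fluorophenyl in place of 3-chlorophenyl on a sulfonyl sulfur. For the measured compounds named here, no measured step bears on this change; the only information is that every measured member of the series sits at the limit. The estimated step that the limit leaves unreadable from compound 1 to compound 4 is therefore expected to be none beyond the scatter, with compound 4 expected to remain at the limit rather than to move. Compound 4 is expected to give 100000 nM in this assay, estimated between 30000 nM and 500000 nM, and most likely to be reported as a limit only.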

Compound 4, half-maximal inhibitory concentration: > 63000 nM
Compound 4: no number, only a limit; the forecaster's own chance of this, stated with the estimate: 85%; the middle value does not contradict the limit.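

In this assay compound 4 gives > 63000 nM, which is a limit of the assay and not a number. No step from compound 1 to compound 4 can be read, as every value in the series stands at the same point: the limit of > 63000 nM in this assay, at which 4 of the 4 values shown sit.

The compounds shown leave open whether any substituent on the sulfonyl sulfur gives a measurable inhibition in this assay.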